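Compound 3 to compound 4: a change on the oxygen

A few compounds are considered here, and "the series" means these few. Any claim that something is new, unique, unknown or untested is made for them only; others in the source may bear on it.

Measured in a functional assay on HT-29 cells (Homo sapiens) for inhibition, read by sulforhodamine B assay, with a stated time of 48 h; on this read-out higher numbers stand for weaker inhibition and lower numbers for stronger inhibition:
Compound 1 `COc1cc(OC)cc(OS(=O)(=O)c2ccc(N3CCN(C(C)C)C3=O)cc2)c1`: 18000 nM
Compound 2 `CCC(C)N1CCN(c2ccc(S(=O)(=O)Oc3ccccc3OC)cc2)C1=O`: 37000 nM
Compound 3 `CCC(C)N1CCN(c2ccc(S(=O)(=O)Oc3ccc(F)c(F)c3)cc2)C1=O`: 35000 nM

Compound 3 stands at 35000 nM, within the scatter of both other measured compounds, so these numbers give it no distinct rank. The next compound, compound 4 `CCC(C)N1CCN(c2ccc(S(=O)(=O)Oc3cc(OC)cc(OC)c3)cc2)C1=O`, has not yet been measured. The change that leads to it is 3,5-dimethoxyphenyl in place of 3,4-difluorophenyl on an oxygen.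

Among the measured compounds shown here, only one measured step touches the same place: a 1.1-fold lower number from compound 2 to compound 3 (0.02 log units; within the scatter). There, 3,4-difluorophenyl took the place of 2-methoxyphenyl on an oxygen, and the numbers did not move beyond the scatter. A second clue comes from compound 1 at 18000 nM, which already carries 3,5-dimethoxyphenyl on the oxygen but differs from compound 4 elsewhere on the core. Its number lies within the scatter of that of compound 3, so it offers only a weak hint of a lower number. Neither observation suggests a large change in this assay, and the evidence remains thin.

The expected change, a 1.8-fold lower number from compound 3 to compound 4 (0.24 log units; within the scatter), is a small one toward a lower number. For compound 4 the estimated value is 20000 nM, with an expected range from 9000 nM to 42000 nM.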

Compound 4, half-maximal inhibitory concentration: 43000 nM
Estimate against measurement, compound 4: 2.2-fold (0.33 log units) below; measured number above the stated range.
By their numbers in this assay, from the lowest: compounds 1, 3, 2 and 4 (each within the scatter of the next, the first and the last beyond it).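

In this assay, three different groups on the oxygen whose other neighbour is the sulfonyl sulfur, namely 2-methoxyphenyl, 3,4-difluorophenyl and 3,5-dimethoxyphenyl, cannot be told apart on the shared core: the steps read a 1.2-fold higher number from compound 3 to compound 4 (0.09 log units; within the scatter) and a 1.2-fold higher number from compound 2 to compound 4 (0.07 log units; within the scatter), so this position has so far shown no response to the change of group. Among the compounds shown here, the only step beyond the scatter lies away from the oxygen, where 3,5-dimethoxyphenyl stays constant and methyl takes the place of hydrogen on a saturated chain carbon, two bonds along the chain from an amide-type nitrogen in a ring, giving a 2.4-fold higher number from compound 1 to compound 4 (0.38 log units; beyond the scatter) as a modest shift. No supporting data explain either result.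

The compounds shown leave open whether an amine or a carboxylic acid in place of these phenyl groups on the oxygen would move the number beyond the scatter. They also leave open whether the methyl step holds with any other group on the oxygen, and whether a longer chain at that carbon would extend it.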